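Removing the aryl substituent in a succinimide-piperazine amide series

The source may report more compounds than this note shows. Statements on the series, on what has been measured and on what is new or still open speak of the compounds shown alone.

Measured compounds:
- compound 1 `CC(C(=O)N1CCN(c2ccccc2)CC1)N1C(=O)CCC1=O`: 50%
- compound 2 `CCC(C(=O)N1CCN(c2cccc(F)c2)CC1)N1C(=O)CCC1=O`: 75%
- compound 3 `CCC(C(=O)N1CCN(c2cccc(C(F)(F)F)c2)CC1)N1C(=O)CCC1=O`: 100%

In a functional assay on the whole organism (strain Swiss) with Mus musculus as the target, in the maximal electroshock model, with a stated time of 1 h, at a dose of 300 mg/kg by the intraperitoneal route (on this read-out higher numbers stand for a stronger effect at the one dose given and lower numbers for a weaker effect), compound 3 gives 100%, the highest of the three numbers; the nearest is compound 2 with 75%, and compound 1 with 50% lies furthest below, both gaps beyond the scatter. Among the measured compounds shown here, the one single-point step among the measured compounds is a number 25 percentage points higher from compound 2 to compound 3 (beyond the scatter), which runs toward compound 3.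

Compound 4 `CCC(C(=O)N1CCN(c2ccccc2)CC1)N1C(=O)CCC1=O` is not yet measured. It differs from compound 3 by hydrogen in place of trifluoromethyl on an aromatic carbon. For the measured compounds named here, the measured step from compound 2 to compound 3 bears on this change only in part, since there the ring kept a substituent; compound 1, which carries the same unsubstituted ring but a shorter chain on the carbon bearing the succinimide, shows 50%, and no step to compound 4 is computed for that pair. Given a number 25 percentage points higher from compound 2 to compound 3 (beyond the scatter), compound 4 is expected to fall beyond the scatter below compound 3, by a step of about a number 50 percentage points lower from compound 3 to compound 4 (beyond the scatter). Compound 4 is thus estimated at 50% in this assay, in the range 25% to 75%.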

Compound 4, a percentage reported as activity, at one dose (the size of the read-out at that dose, not a potency): 75%
For compound 4 the middle estimate is 25 percentage points below the measured one, and the stated range covers the measured number.
By their numbers in this assay, from the lowest: compound 1; then compounds 2 and 4 (each within the scatter of the next); then compound 3.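

In this assay, the bare ring now gives a direct reading of the aromatic position: hydrogen in place of trifluoromethyl gives a number 25 percentage points lower from compound 3 to compound 4 (beyond the scatter), whereas hydrogen in place of fluoro gives no change at the digits printed from compound 2 to compound 4 (within the scatter), so at this position only trifluoromethyl separates from hydrogen. With the unsubstituted ring held constant, the chain can also be read on its own: methyl in place of hydrogen on the saturated chain carbon gives a number 25 percentage points higher from compound 1 to compound 4 (beyond the scatter). No measurement shown accounts for either difference.

Open, on these data alone, is whether a chlorine atom or a methoxy group on the same aromatic carbon would stay with hydrogen and fluoro or move with trifluoromethyl. Among the compounds shown here, also open is whether a longer chain on the carbon bearing the succinimide would extend the step seen with methyl, and the single-dose read-out gives no potency for any compound.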